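Bromo for Methyl: Estimating Compound 4 in this assay

The source may report more compounds than this note shows. Statements on the series, on what has been measured and on what is new or still open speak of the compounds shown alone.

Compound 1 `O=C1C(Nc2ccccc2)=CC(=O)c2ncncc21`: 0.01 ug/mL
Compound 2 `CCOc1ccc(NC2=CC(=O)c3ncncc3C2=O)cc1`: 0.03 ug/mL
Compound 3 `Cc1ccc(NC2=CC(=O)c3ncncc3C2=O)cc1`: 0.13 ug/mL

In a functional assay on XF498 cells (Homo sapiens) for cytotoxicity, read by MTT assay, with a stated time of 72 h (a higher number here means a weaker inhibitor, a lower number a stronger inhibitor), compound 3 gives the highest number of the three; it sits a 4.3-fold higher number from compound 2 to compound 3 (0.64 log units; beyond the scatter) and a 13-fold higher number from compound 1 to compound 3 (1.11 log units; beyond the scatter). Compound 4 `O=C1C(Nc2ccc(Br)cc2)=CC(=O)c2ncncc21` differs from compound 3 in one place: bromo in place of methyl on an aromatic carbon. Going by the values given here, no measured pair swaps methyl for bromo, so the steps from compound 1 and compound 2 to compound 3 bear on it only indirectly: they show that the group at this position moves the number by modest to large amounts. With bromo being a single heavy atom like methyl, the expected step of a 1.3-fold lower number from compound 3 to compound 4 (0.11 log units; within the scatter) is small, in either direction. Compound 4 is therefore estimated at 0.1 ug/mL, with a range from 0.02 ug/mL to 0.5 ug/mL.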

Compound 4, half-maximal inhibitory concentration: 0.03 ug/mL
Estimate against measurement, compound 4: 3.3-fold (0.52 log units) above; measured number inside the range.
By their numbers in this assay, from the lowest: compound 1; then compounds 2 and 4 (each within the scatter of the next); then compound 3.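

Two groups of one heavy atom each are not interchangeable at this place: in this assay bromo in place of methyl gives a 4.3-fold lower number from compound 3 to compound 4 (0.64 log units; beyond the scatter) and so restores much of what methyl gave up. Bromo in place of ethoxy gives no change at the digits printed from compound 2 to compound 4 (within the scatter), while bromo in place of hydrogen gives a 3.0-fold higher number from compound 1 to compound 4 (0.48 log units; beyond the scatter), so compound 1, with no group here, keeps the lowest number. Nothing measured here explains these differences.

As far as these compounds go, whether an amine or a carboxylic acid at this place would bring the number down to that of compound 1 stays open. So does whether bromo elsewhere on the same ring would behave alike.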